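This account rests on a few compounds, and the source may have more. Where it says the series, first, only, none or still open, it means among the compounds named here.

Measured compounds:
compound 1 `CCOC(=O)C1=CC(c2ccc(Br)cc2)C2=C(CC(C)(C)CC2=O)N1`, in an assay on isolated protein for inhibition of glucose-6-phosphatase catalytic subunit 1 (Homo sapiens), read by inositol phosphate accumulation, with a stated time of 30 min, tested at 100 uM (on this read-out lower numbers stand for less inhibition and higher numbers for more inhibition at the one concentration tested (going by the name of the read-out)), compound 1 gives "not active" (no number reported)
compound 2 `CC1(C)CC(=O)C2=C(C1)NC(C(=O)O)=CC2c1ccc(F)cc1`, in this assay compound 2 gives 16.8%

Within the data shown here, compound 2 holds the only number reported; compound 1 is the one further entry, and for it no number is given, only the statement that it is not active. So there is no measured step to lean on, and compound 2 stands alone as the single quantified point.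

Compound 3 `CCOC(=O)C1=CC(c2ccc(F)cc2)C2=C(CC(C)(C)CC2=O)N1` is not yet measured. Against compound 2 the change is ethyl in place of hydrogen on an oxygen next to a carbonyl group, so the carboxy of compound 2 becomes an ethoxycarbonyl. Among the measured compounds shown here, compound 1, which gives "not active" (no number reported), also carries an ethoxycarbonyl, and that is the only guide available. Because compound 1 gives "not active" (no number reported), the expectation in this assay is a step downward from compound 2, or at most one that stays within the scatter, rather than any rise.

For compound 3 the estimate is 8%, with a range from 0% to 20%, which corresponds to an expected step of a number 8.8 percentage points lower from compound 2 to compound 3 (within the scatter).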

Compound 3, a percentage reported as inhibition, at one concentration (the size of the read-out at that concentration, not a potency): "not active" (no number reported)
The entry for compound 3 holds no number; the estimate stays without a comparison.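

In this assay, among these compounds, compound 3 has no number, so no step from compound 2 to compound 3 can be read. No measured evidence bears on this result. The compounds shown leave open how large any difference between the carboxy of compound 2 and the ethoxycarbonyl of compound 3 is on this read-out.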